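This account rests on a few compounds, and the source may have more. Where it says the series, first, only, none or still open, it means among the compounds named here.

Values in a functional assay on HOP-62 cells (Homo sapiens) for inhibition, read by sulforhodamine B assay (a higher number here means a weaker inhibitor of growth, a lower number a stronger inhibitor of growth), so far

compound 1 `Cc1ccc2[nH]c(-c3ccc(-c4ccc(-c5ccc(N(C)C)cc5)cc4)cc3)nc2c1` gives 4230 nM
compound 2 `CN(C)c1ccc(-c2ccc(-c3ccc(-c4nc5ccccc5[nH]4)cc3)cc2)cc1` gives 100000 nM
compound 3 `CN(C)c1ccc(-c2ccc(-c3ccc(-c4nc5c(O)cccc5[nH]4)cc3)cc2)cc1` gives 8250 nM

Compound 1 sits level with its nearest neighbour (a 2.0-fold higher number from compound 1 to compound 3 (0.29 log units; within the scatter)) and well apart from the remaining compound (a 24-fold higher number from compound 1 to compound 2 (1.37 log units; beyond the scatter)). The next change, to compound 4 (`Cc1ccc2[nH]c(-c3ccc(-c4ccc(-c5ccc(F)cc5)cc4)cc3)nc2c1`), is fluoro in place of dimethylamino on an aromatic carbon, para to a large group (fluoro in place of dimethylamino on an aromatic carbon). Among the compounds with values here, all three measured compounds carry the dimethylamino group, so no measured step touches this place, and the data give no direction for this change in this assay on their own. The measured steps bear on it only indirectly. Compound 4 keeps the methyl whose replacement by hydrogen gave a large step (a 24-fold higher number from compound 1 to compound 2 (1.37 log units; beyond the scatter)). The step with hydroxy in place of hydrogen (a 12-fold lower number from compound 2 to compound 3 (1.08 log units; beyond the scatter)) is also large, so a single small change can move the number far in this series, and the range has to stay wide. With that methyl kept, no step beyond the scatter is expected. The expected step is small (a 1.2-fold higher number from compound 1 to compound 4 (0.07 log units; within the scatter)). For compound 4 the estimated value is 5000 nM within an expected range from 1500 nM to 20000 nM as the working figures.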

Compound 4, concentration for 50% growth inhibition: 33500 nM
Estimate against measurement, compound 4: 6.7-fold (0.83 log units) below; the whole stated range lies below it.
By their numbers in this assay, from the lowest: compounds 1 and 3 (each within the scatter of the next); then compound 4; then compound 2.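

In this assay, within the data shown here, the position held by dimethylamino, on an aromatic carbon para to a large group, is not a neutral place: fluoro in place of dimethylamino gives a 7.9-fold higher number from compound 1 to compound 4 (0.90 log units; beyond the scatter) and is the first measured step at this position. Compound 1 and compound 4 both keep the 5-methyl-1H-benzimidazol-2-yl group, so that group alone does not hold the number at the level seen for compound 1, and the far end of the molecule also counts in this series. Nothing measured on these compounds accounts for the size of this step.

With a single replacement shown here, the loss of dimethylamino and the arrival of fluoro cannot be told apart, and a comparison with hydrogen, methoxy, a primary amine or morpholine at the same position would be needed to separate them. Also open is whether fluoro in place of dimethylamino gives a step of similar size when the hydroxy group of compound 3 replaces the methyl, as the change is shown only with the methyl in place.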